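The compounds below may be only part of what the source reports. "The series", "measured", "known", "first", "only" and "open" are said of these compounds alone.

Working notes on the series. Compound 1 `COc1ccc2c(=O)c(-c3cc(OC)c(OC)cc3OC)coc2c1` carries an unsubstituted oxygen on the shared core; in a functional assay on HUVEC cells (Homo sapiens) for antiproliferative activity, read by MTT assay, with a stated time of 24 h (on this read-out higher numbers stand for weaker inhibition and lower numbers for stronger inhibition), compound 1 gives > 10000 nM, which is a limit of the assay and not a number. Within the data shown here, compound 2 `COc1cc(OC)c(-c2coc3cc(OCc4cccc(F)c4)ccc3c2=O)cc1OC` is the benzylated analogue, and in this assay compound 2 gives 5300 nM, the only number recorded so far. The step of an at least 1.8-fold lower number from compound 1 to compound 2 (0.27 log units; that floor lies within the scatter) is read against the limit of > 10000 nM in this assay, at which 1 of the 2 values shown sits, and cannot be sized beyond that floor.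

Compound 3 `COc1cc(OC)c(-c2coc3cc(OCc4cccc(C(F)(F)F)c4)ccc3c2=O)cc1OC` differs from compound 2 in one place: trifluoromethyl in place of fluoro on an aromatic carbon. Among the measured compounds shown here, no measured step concerns a change of this kind; the one recorded step covers the whole benzyl group and not its substituent. The expectation for this assay is therefore a step of about a 1.3-fold lower number from compound 2 to compound 3 (0.12 log units; within the scatter), not resolved from the scatter. Compound 3 is estimated at 4000 nM, within 1500 nM to 12000 nM.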

Compound 3, half-maximal inhibitory concentration: > 10000 nM
Compound 3: a limit, no number; the forecaster's own chance of this, stated with the estimate: 15%; at least 2.5-fold (0.39 log units) between middle value and limit.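

Trifluoromethyl in place of fluoro, on an aromatic carbon meta to a large group, gives an at least 1.8-fold higher number from compound 2 to compound 3 (0.27 log units; that floor lies within the scatter), the first reading on the substituent of the benzyl group and not on the benzyl group as a whole; with that floor within the scatter, the step does not separate the two compounds. Compound 3 gives a limit of the assay and not a number. The step from compound 1 to compound 3 cannot be read, and one limit now bounds most of the series: the limit of > 10000 nM in this assay, at which 2 of the 3 values shown sit.

The compounds shown leave open how a methoxy, a nitrile or an amine on that aromatic carbon would read in this assay, and whether the unsubstituted benzyl group would give a number. Among these compounds, with compound 2 as the only compound holding a number, no trend across substituents can be stated.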